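The compounds below may be only part of what the source reports. "The series", "measured", "known", "first", "only" and "open" are said of these compounds alone.

Compound 1 `CN1CCN(CCCCCCn2c3c(c4ccccc42)C(=O)c2c[n+]([O-])c4ccccc4c2C3=O)CC1` carries a 5-(4-methylpiperazin-1-yl)pentyl chain on the shared core. Among the compounds with values here, in a functional assay on MDA-MB-231 cells (Homo sapiens) for cytotoxicity, read by MTT assay, with a stated time of 72 h (on this read-out lower numbers stand for stronger inhibition and higher numbers for weaker inhibition), compound 1 gives 2400 nM, one of only two plain numbers in hand. Compound 2 `O=C1c2c[n+]([O-])c3ccccc3c2C(=O)c2c1c1ccccc1n2Cc1cn(CC(O)CO)nn1` gives 1290 nM, and putting 1-(2,3-dihydroxypropyl)-1H-1,2,3-triazol-4-yl in place of 5-(4-methylpiperazin-1-yl)pentyl on a saturated chain carbon bound to an aromatic nitrogen amounts to a 1.9-fold lower number from compound 1 to compound 2 (0.27 log units; within the scatter). Compound 3 `CC1(C)OC[C@@H](Cn2cc(Cn3c4c(c5ccccc53)C(=O)c3c[n+]([O-])c5ccccc5c3C4=O)nn2)O1` is recorded only as a limit, > 1000 nM. Because of the limit of > 1000 nM in this assay, at which 1 of the 3 values shown sits, the step that the limit leaves unreadable from compound 2 to compound 3 cannot be sized.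

Compound 4 `CCCN1CCN(CCCCn2c3c(c4ccccc42)C(=O)c2c[n+]([O-])c4ccccc4c2C3=O)CC1` differs from compound 1 in that (4-propylpiperazin-1-yl in place of 2-(4-methylpiperazin-1-yl)ethyl on a saturated chain carbon, four bonds along the chain from an aromatic nitrogen). Within the data shown here, no measured step rearranges the chain and piperazine in this way; the only readable step, which swapped the whole side chain between compound 1 and compound 2, stayed within the scatter. The step of no change at the digits printed from compound 1 to compound 4 (within the scatter) is therefore expected to amount to nothing beyond the scatter. Compound 4 is estimated to give 2400 nM, with a likely range from 1000 nM to 5500 nM.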

Compound 4, half-maximal inhibitory concentration: 2980 nM
Estimate against measurement, compound 4: 1.2-fold (0.09 log units) below; low and high end bracket the measured number.
By their numbers in this assay, from the lowest: compounds 2, 1 and 4 (each within the scatter of the next, the first and the last beyond it).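

Swapping the arrangement of the same atoms, with 4-propylpiperazin-1-yl in place of 2-(4-methylpiperazin-1-yl)ethyl on a saturated chain carbon, four bonds along the chain from an aromatic nitrogen, gives a 1.2-fold higher number from compound 1 to compound 4 (0.09 log units; within the scatter). In this assay, moving carbons from the chain to the end of the piperazine therefore leaves the number within the scatter. Within the data shown here, the new compound also provides the first readable step beyond the scatter, though a modest one and a change of the whole side chain: a 2.3-fold higher number from compound 2 to compound 4 (0.36 log units; beyond the scatter).

Compound 3, recorded only as a limit, cannot be placed in this order because of that limit: the limit of > 1000 nM in this assay, at which 1 of the 4 values shown sits. From the compounds shown here alone, whether a morpholine ring in place of the piperazine, or a butyl group on its nitrogen, would shift the number stays open.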